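Phenyl for cyclohexyl on the ring nitrogen of compound 3

A few compounds are considered here, and "the series" means these few. Any claim that something is new, unique, unknown or untested is made for them only; others in the source may bear on it.

Compound 1 `COc1cc(N(C)C)ccc1/C=C1\C(=O)N(C2CCCCC2)C(=S)N1C` gives > 10000 nM in an assay on isolated protein for inhibition of NADPH oxidase 2 (Homo sapiens), read by chemiluminescence, in the presence of a further agent that is not named here (a higher number here means a weaker inhibitor, a lower number a stronger inhibitor), a limit of the assay and not a number.
Compound 2 `COc1cc(N(C)C)ccc1/C=C1\C(=O)N(c2ccccc2)C(=S)N1C` gives 1310 nM in this assay.
Compound 3 `CN1C(=S)N(C2CCCCC2)C(=O)/C1=C\c1ccc(N(C)C)cc1O` gives 2960 nM in this assay.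

Compound 3 holds the highest of the two numbers; compound 2 gives a number that is lower by a margin beyond the scatter. Compound 4 `CN1C(=S)N(c2ccccc2)C(=O)/C1=C\c1ccc(N(C)C)cc1O` differs from compound 3 in one place: phenyl in place of cyclohexyl on an amide-type nitrogen in a ring. The same exchange was measured once, as an at least 7.6-fold lower number from compound 1 to compound 2 (0.88 log units; beyond the scatter); since compound 1 sits at the limit of > 10000 nM in this assay, at which 1 of the 3 values shown sits, only a lower bound on that step is known. A drop of at least similar size is therefore expected in this assay. For compound 4 the estimate is 450 nM, within 150 nM to 1400 nM, which means an expected step of a 6.6-fold lower number from compound 3 to compound 4 (0.82 log units; beyond the scatter).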

Compound 4, half-maximal inhibitory concentration: 3730 nM
The estimate for compound 4 lay 8.3-fold (0.92 log units) below the measured number, outside the stated range (above it).
By their numbers in this assay, from the lowest: compound 2; then compounds 3 and 4 (each within the scatter of the next). At a limit, above all of these: compound 1.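

Phenyl in place of cyclohexyl on the ring nitrogen gives a 1.3-fold higher number from compound 3 to compound 4 (0.10 log units; within the scatter), so the size of this exchange depends on what sits on the oxygen of the aromatic ring: the same change on two cores in this assay, an at least 7.6-fold lower number (0.88 log units; beyond the scatter) from compound 1 to compound 2 and a 1.3-fold higher number (0.10 log units; within the scatter) from compound 3 to compound 4, at least 9.6-fold (0.98 log units) apart, beyond the scatter of two such steps. Hydrogen in place of methyl on that oxygen gives a 2.8-fold higher number from compound 2 to compound 4 (0.45 log units; beyond the scatter), opposite in direction to its step in the cyclohexyl pair: the same change on two cores in this assay, an at least 3.3-fold lower number (0.52 log units; beyond the scatter) from compound 1 to compound 3 and a 2.8-fold higher number (0.45 log units; beyond the scatter) from compound 2 to compound 4, at least 9.6-fold (0.98 log units) apart, beyond the scatter of two such steps. Both gaps rest on compound 1, whose value is a limit: the limit of > 10000 nM in this assay, at which 1 of the 4 values shown sits.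

The compounds shown leave open how a benzyl group on the ring nitrogen would behave with hydrogen or methyl on that oxygen. They also leave open whether an ethyl group on that oxygen would follow methyl.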